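Removing the Butyl Chain: What the Growth Assay May Show

The source may hold more compounds than are shown below. What is called first, only, known or untested is meant among the compounds shown, and "the series" means these compounds.

Among the measured compounds shown here, in a functional assay on MCF7 cells (Homo sapiens) for inhibition, read by fluorescence, with a stated time of 72 h (on this read-out higher numbers stand for weaker inhibition of growth and lower numbers for stronger inhibition of growth), compound 2 `CCCCc1cc2nn(-c3ccccc3)cc2c(C)n1` gives 11100 nM, and this is the only number reported. Compound 1 `Cc1nc(CCO)cc2nn(-c3ccccc3)cc12` carries a hydroxyethyl chain where compound 2 carries butyl, and in this assay compound 1 gives > 100000 nM, which is a limit of the assay rather than a number, the same limit as the limit of > 100000 nM in this assay, at which 1 of the 2 values shown sits. For the measured compounds named here, the one measured step, an at least 9.0-fold lower number from compound 1 to compound 2 (0.95 log units; beyond the scatter), therefore shows that the chain at this position matters: a butyl chain gives a stronger growth inhibition than a hydroxyethyl chain, by at least a modest margin. Compound 3 `Cc1nccc2nn(-c3ccccc3)cc12` drops the chain entirely: hydrogen in place of butyl on an aromatic carbon. No measured step removes the chain altogether, so the size can only be inferred from the one step shown. Since the shorter, hydroxy-bearing chain already weakened inhibition, compound 3 is expected to inhibit growth more weakly than compound 2, with an estimated step of a 4.5-fold higher number from compound 2 to compound 3 (0.65 log units; beyond the scatter). Compound 3 is therefore estimated at 50000 nM, within a range of 15000 nM to 200000 nM.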

Compound 3, concentration for 50% growth inhibition: > 100000 nM
Compound 3: a limit, no number; the forecaster's own chance of this, stated with the estimate: 35%; middle value at least 2.0-fold (0.30 log units) away from the limit.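

In this assay, replacing butyl with hydrogen gives an at least 9.0-fold higher number from compound 2 to compound 3 (0.95 log units; beyond the scatter), so the butyl chain on this aromatic carbon accounts for at least a modest part of the growth inhibition seen with compound 2. The result for compound 3 is a limit and not a number, so only compound 2 gives a measured value, and the other two compounds share this limit: the limit of > 100000 nM in this assay, at which 2 of the 3 values shown sit. The step between compound 1 and compound 3 cannot be read, so hydrogen and 2-hydroxyethyl cannot be ranked at this position.

Going by these compounds, what remains open is whether a longer chain, such as hexyl, would lower the number further, or a shorter ethyl chain would keep any of the inhibition. On these data alone, it is also open how an amine at the end of the chain would behave.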